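Propylurea sulfonate esters: from isopropyl to iodo

This account rests on a few compounds, and the source may have more. Where it says the series, first, only, none or still open, it means among the compounds named here.

Measured compounds in a functional assay on MCF7 cells (Homo sapiens) for antiproliferative activity, read by sulforhodamine B assay, with a stated time of 48 h; on this read-out higher numbers stand for weaker inhibition and lower numbers for stronger inhibition:
compound 1 `CCCCCC(=O)Nc1ccc(S(=O)(=O)Oc2ccccc2I)cc1` gives 10000 nM
compound 2 `CC(C)C(=O)Nc1ccc(S(=O)(=O)Oc2ccccc2I)cc1` gives 8100 nM
compound 3 `CCCNC(=O)Nc1ccc(S(=O)(=O)Oc2ccccc2C(C)C)cc1` gives 2700 nM

Compound 3 stands lowest of the three numbers in this assay. Its nearest neighbour is compound 2, whose number is higher by a margin beyond the scatter, and compound 1 lies further still. Going by the values given here, the one single-point step among the measured compounds, a 1.2-fold lower number from compound 1 to compound 2 (0.09 log units; within the scatter), concerns the carbonyl substituent and stays within the scatter.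

Compound 4 `CCCNC(=O)Nc1ccc(S(=O)(=O)Oc2ccccc2I)cc1` arises from compound 3 by one change: iodo in place of isopropyl on an aromatic carbon. Among the compounds with values here, no measured pair isolates this exchange. Compounds 1 and 2 carry the iodo group but differ from compound 3 in the carbonyl part as well, so their higher numbers cannot be assigned to the iodo group alone. The step from compound 3 to compound 4 is therefore expected to be modest and uncertain, and on balance the number is expected to rise somewhat, by a 1.7-fold higher number from compound 3 to compound 4 (0.22 log units; within the scatter). Compound 4 is estimated at 4500 nM in this assay, with a range from 1500 nM to 13000 nM.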

Compound 4, half-maximal inhibitory concentration: 2900 nM
Compound 4: middle estimate off by 1.6-fold (0.19 log units), on the high side; the range from low to high includes it.
By their numbers in this assay, from the lowest: compounds 3 and 4 (each within the scatter of the next); then compounds 2 and 1 (each within the scatter of the next).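

In this assay, exchanging isopropyl for iodo on this aromatic carbon, with three carbon atoms leaving and one iodine entering, gives a 1.1-fold higher number from compound 3 to compound 4 (0.03 log units; within the scatter), so this position accepts either group while propylamino stays on the carbonyl carbon. With iodo held constant, the carbonyl substituent can now be read on its own: a 2.8-fold lower number from compound 2 to compound 4 (0.45 log units; beyond the scatter) accompanies propylamino in place of isopropyl and a 3.4-fold lower number from compound 1 to compound 4 (0.54 log units; beyond the scatter) accompanies propylamino in place of pentyl, so among these compounds the higher numbers of compound 1 and compound 2 go with the carbonyl substituent and not with the iodo group. No supporting information bears on what lies behind either of these results.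

The compounds shown leave open whether iodo and isopropyl would also match each other with isopropyl or pentyl on the carbonyl carbon, and whether a much smaller group at this aromatic position, such as fluoro or methoxy, would keep the number in the same range. They also leave open how a longer chain, such as butylamino, or a cyclic amine in place of propylamino would fare.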